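From 1,2-dihydroxyethyl to cyclopropylcarbamoyl in one step

A few compounds are considered here, and "the series" means these few. Any claim that something is new, unique, unknown or untested is made for them only; others in the source may bear on it.

Compound 1 `CNC(=O)C[C@@H]1C[C@@H](c2ccc(Cl)c(Cl)c2)[C@H](NC(=O)c2cc(-c3c(Cl)cnn3C)c(Cl)o2)CN1`: 1130 nM
Compound 2 `Cn1ncc(Cl)c1-c1cc(C(=O)N[C@@H]2CN[C@H](CC(O)CO)C[C@H]2c2ccc(Cl)c(Cl)c2)oc1Cl`: 1610 nM
Compound 3 `Cn1ncc(Cl)c1-c1cc(C(=O)N[C@@H]2CN[C@H](CC(N)=O)C[C@H]2c2ccc(Cl)c(Cl)c2)oc1Cl`: 1000 nM

These numbers come from a functional assay on OVCAR-8 cells (Homo sapiens) for antiproliferative activity; a lower number here means a stronger inhibitor, a higher number a weaker inhibitor. Compound 2 gives the highest of the three, yet its gaps to compound 1 and to compound 3 are both within the scatter, so the three compounds cannot be told apart. Compound 4 `Cn1ncc(Cl)c1-c1cc(C(=O)N[C@@H]2CN[C@H](CC(=O)NC3CC3)C[C@H]2c2ccc(Cl)c(Cl)c2)oc1Cl` carries cyclopropylcarbamoyl in place of 1,2-dihydroxyethyl on a saturated chain carbon bound to a saturated ring carbon. For the measured compounds named here, two measured steps bear on this change: a 1.4-fold higher number from compound 1 to compound 2 (0.15 log units; within the scatter) and a 1.6-fold lower number from compound 2 to compound 3 (0.21 log units; within the scatter), both within the scatter, meaning that exchanging the 1,2-dihydroxyethyl for a methylcarbamoyl or a carbamoyl left the number essentially where it was. The step of a 1.5-fold lower number from compound 2 to compound 4 (0.17 log units; within the scatter) is therefore expected to stay within the scatter as well. Compound 4 is estimated at 1100 nM, with a range from 500 nM to 2500 nM.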

Compound 4, half-maximal inhibitory concentration: 580 nM
The estimate for compound 4 lay 1.9-fold (0.28 log units) above the measured number; the measured number falls inside the stated range.
By their numbers in this assay, from the lowest: compounds 4, 3, 1 and 2 (each within the scatter of the next, the first and the last beyond it).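

In this assay, for the compounds shown here, cyclopropylcarbamoyl is the first replacement of 1,2-dihydroxyethyl at this position to move the number beyond the scatter (a 2.8-fold lower number from compound 2 to compound 4 (0.44 log units; beyond the scatter)). Among the amides, however, cyclopropyl on the amide-type nitrogen stays within the scatter against both hydrogen (a 1.7-fold lower number from compound 3 to compound 4 (0.24 log units; within the scatter)) and methyl (a 1.9-fold lower number from compound 1 to compound 4 (0.29 log units; within the scatter)), so it cannot be separated from either. Nothing measured here explains the step. From the compounds shown here alone, whether cyclobutyl on that nitrogen would lower the number further remains open. So does the effect of an amine or a carboxylic acid in place of the amide on this chain.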